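The compounds below may be only part of what the source reports. "The series", "measured", "known", "first", "only" and "open" are said of these compounds alone.

Working notes on the series. Among the measured compounds shown here, in a functional assay on A549 cells (Homo sapiens) for inhibition, read by MTT assay, with a stated time of 72 h (on this read-out lower numbers stand for stronger inhibition and higher numbers for weaker inhibition), compound 2 `CN(C(=O)NC(=O)c1ccccc1F)c1nc(C(F)(F)F)c(C(=O)N/N=C/c2ccccc2C(F)(F)F)s1` gives 6.32 ug/mL, the only number in this set. Compound 1 `CNc1nc(C)c(C(=O)N/N=C/c2ccccc2C(F)(F)F)s1` gives > 100 ug/mL in this assay, which is a limit of the assay rather than a number. Compound 1 therefore sits at the limit of > 100 ug/mL in this assay, at which 1 of the 2 values shown sits, and, like compound 3, it lacks the ((2-fluorophenyl)carbonyl)carbamoyl group that compound 2 carries. Compound 3 `CNc1nc(C(F)(F)F)c(C(=O)N/N=C/c2ccccc2C(F)(F)F)s1` is not yet measured. It differs from compound 2 in one place: hydrogen in place of ((2-fluorophenyl)carbonyl)carbamoyl on a nitrogen on an aromatic ring. For the measured compounds named here, no measured step of this kind exists. The expectation is a loss of inhibition well beyond the scatter, the step from a 7.9-fold higher number from compound 2 to compound 3 (0.90 log units; beyond the scatter). Compound 3 is accordingly expected to give around 50 ug/mL in this assay, between 15 ug/mL and 150 ug/mL, with a real chance that only a limit is returned.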

Compound 3, half-maximal inhibitory concentration: > 100 ug/mL
Compound 3: no number, only a limit; the forecaster's own chance of this, stated with the estimate: 45%; middle value at least 2.0-fold (0.30 log units) from the limit.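

In this assay, among the compounds shown here, hydrogen in place of ((2-fluorophenyl)carbonyl)carbamoyl on a nitrogen on an aromatic ring gives an at least 15-fold higher number from compound 2 to compound 3 (1.19 log units; beyond the scatter) and is the first readable step, so at this position the measurable inhibition depends on that group. The step from compound 1 to compound 3, trifluoromethyl in place of methyl on an aromatic carbon, cannot be read, as both values are limits. Compound 3 joins compound 1 at the limit of the assay: the limit of > 100 ug/mL in this assay, at which 2 of the 3 values shown sit.

The compounds shown leave open whether a smaller group on this nitrogen, such as acetyl or methylcarbamoyl, would keep any of the inhibition. They also leave open whether an unsubstituted benzoylcarbamoyl group would match the ((2-fluorophenyl)carbonyl)carbamoyl group.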